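A few compounds are considered here, and "the series" means these few. Any claim that something is new, unique, unknown or untested is made for them only; others in the source may bear on it.

Three compounds sharing one amide-bearing core have been run through an ADME assay on microsomes from liver (Mus musculus), read by LC-MS, using NADPH, tested at 10 uM; a higher number here means that the liver removes a larger share of the compound in one pass, a lower number that the liver removes a smaller share. Compound 1, `O=C(NCc1ccc(F)cc1)c1ccc(N2CCN(S(=O)(=O)c3ccccc3C(F)(F)F)CC2)nn1`, carries a trifluoromethyl on its sulfonyl-bearing ring; in this assay compound 1 gives 0.66. Compound 2, `Cc1ccccc1S(=O)(=O)N1CC2(CN(c3ccc(C(=O)NCc4ccc(F)cc4)nn3)C2)C1`, joins the core to the sulfonamide through a spiro-fused pair of rings, and in this assay compound 2 gives 0.98. Compound 3, `Cc1ccccc1S(=O)(=O)N1CC=C(c2ccc(C(=O)NCc3ccc(F)cc3)nn2)CC1`, uses an unsaturated six-membered linker, and in this assay compound 3 gives 0.94. Compound 1 therefore stands lowest of the three, with compound 3 the nearer of the two and compound 2 the further, both gaps lying beyond the scatter.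

Compound 4, `Cc1ccccc1S(=O)(=O)N1CCN(c2ccc(C(=O)NCc3ccc(F)cc3)nn2)CC1`, keeps the linker of compound 1 and differs from it in one place: methyl in place of trifluoromethyl on an aromatic carbon. Among the measured compounds shown here, no step between two measured compounds isolates this change, since compounds 2 and 3 also differ from compound 1 in their linkers. Their numbers only show that both methyl-bearing compounds sit high. For compound 4 an upward step from compound 1 is expected, of moderate size and probably beyond the scatter, as a number 0.14 higher from compound 1 to compound 4 (beyond the scatter). Compound 4 is thus estimated at 0.8 in this assay, within a range from 0.62 to 0.95.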

Compound 4, hepatic extraction ratio: 0.7
The estimate for compound 4 lay 0.10 above the measured number; low and high end bracket the measured number.
By their numbers in this assay, from the lowest: compounds 1 and 4 (each within the scatter of the next); then compounds 3 and 2 (each within the scatter of the next).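

In this assay the change from 2-(trifluoromethyl)phenyl to 2-methylphenyl, on an aromatic carbon ortho to a large group, can now be read directly on one linker: it is a number 0.040 higher from compound 1 to compound 4 (within the scatter) and so does not separate the two groups at this position. The earlier compounds shown here could not show this, and the methyl-bearing ring alone does not bring a number as high as those of the two compounds with other linkers, since compound 4 gives 0.7 while compound 3 gives 0.94 and compound 2 gives 0.98 with the same ring. Nothing measured here explains why the two groups read alike in this assay.

On these data alone, whether the same change would read alike on the linker of compound 2 or of compound 3 remains open. Also open, as far as these compounds go, is how a chlorine atom, a methoxy group or a nitrile on this same aromatic carbon would read, and whether any of them would move the number beyond the scatter from that of compound 1 or compound 4.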